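Chloro in Place of Hydrogen on the Phenyl of Compound 3

A few compounds are considered here, and "the series" means these few. Any claim that something is new, unique, unknown or untested is made for them only; others in the source may bear on it.

Measured compounds:
compound 1, `CCCCCN(CCCCC)c1nc2c(ncn2-c2ccccc2)c(=O)n1-c1ccc(Cl)cc1`: > 100000 nM
compound 2, `O=c1c2ncn(-c3ccccc3)c2nc(N2CCCCC2)n1-c1ccc(Cl)cc1`: > 100000 nM
compound 3, `CNc1nc2c(ncn2-c2ccccc2)c(=O)n1-c1ccccc1`: > 100000 nM

In a functional assay on HepG2 cells (Homo sapiens) for cytotoxicity, read by MTT assay, with a stated time of 72 h (on this read-out lower numbers stand for stronger inhibition and higher numbers for weaker inhibition), compound 1 gives > 100000 nM, which is a limit of the assay and not a number. Compound 2 gives > 100000 nM in this assay, again a limit. Compound 3 gives > 100000 nM in this assay, also a limit. The step from compound 1 to compound 2, a step that the two limits leave unreadable from compound 1 to compound 2, therefore cannot be read. Compound 3 stands where every measured compound stands, at the limit of > 100000 nM in this assay, at which 3 of the 3 values shown sit; nothing separates it from the others on these numbers.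

Compound 4, `CNc1nc2c(ncn2-c2ccccc2)c(=O)n1-c1ccc(Cl)cc1`, is compound 3 with chloro in place of hydrogen on an aromatic carbon; cut one bond further out, the change reads phenyl to 4-chlorophenyl. Within the data shown here, no measured step follows this exact change. Compounds 1 and 2 both carry a 4-chlorophenyl on the shared core and both sit at the limit, and compound 3 with its plain phenyl sits there as well, so no direction can be read from them. Compound 4 is therefore expected to sit at the limit too, with an estimated 150000 nM in this assay, in a range from 50000 nM to 500000 nM, the expected step being a step that the limit leaves unreadable from compound 3 to compound 4, none beyond the scatter.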

Compound 4, half-maximal inhibitory concentration: > 100000 nM
Compound 4 gave a limit, no number (the forecaster's own chance of this, stated with the estimate: 85%); the middle value does not contradict the limit.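

In this assay compound 4 gives > 100000 nM as a limit of the assay and not a number. Its steps from compound 1, compound 2 and compound 3 therefore cannot be read, and all the compounds stand together: the limit of > 100000 nM in this assay, at which 4 of the 4 values shown sit. The compounds shown leave open whether chloro in place of hydrogen, or any other change among them, alters cytotoxicity at all.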